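The source may hold more compounds than are shown below. What is called first, only, known or untested is meant among the compounds shown, and "the series" means these compounds.

In an ADME assay on microsomes from liver (Mus musculus) for metabolic stability, read by HPLC, with a stated time of 30 min (on this read-out lower numbers stand for a less stable compound and higher numbers for a more stable compound), compound 1 `COc1ccc(NC(=O)C(=O)c2c[nH]c3cc(C)ccc23)cc1` gives 89.1% and compound 2 `COc1ccc(NC(=O)C(=O)c2c[nH]c3cc(Cl)ccc23)cc1` gives 87.3% with no separation beyond the scatter. Compound 3 `O=C(Nc1ccc(-n2cccn2)cc1)C(=O)c1c[nH]c2cc(Cl)ccc12` departs from compound 2 by 1H-pyrazol-1-yl in place of methoxy on an aromatic carbon with 1H-pyrazol-1-yl in place of methoxy on an aromatic carbon. Going by the values given here, the one measured step, a number 1.8 percentage points lower from compound 1 to compound 2 (within the scatter) for chloro in place of methyl on an aromatic carbon, leaves the methoxy untouched, so this change has no measured precedent. In this assay the estimated step is a number 6.3 percentage points lower from compound 2 to compound 3 (within the scatter) and is expected to stay within the scatter, though with wide uncertainty. For compound 3 the expected value is 81% within a range of 58% to 95% as estimated.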

Compound 3, percent of the compound remaining: 96.7%
Compound 3: middle estimate off by 15.7 percentage points, on the low side, and the stated range ends below it.
By their numbers in this assay, from the lowest: compounds 2, 1 and 3 (each within the scatter of the next).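

In this assay, the aromatic carbon para to a large group takes 1H-pyrazol-1-yl in place of methoxy, with a number 9.4 percentage points higher from compound 2 to compound 3 (within the scatter). Going by these compounds alone, this is the first measured change at this position, and it shows that a five-membered aromatic ring can stand there with compound 3 remaining within the scatter of compound 2. Nothing measured here bears on the reason for this result. Open, on these data alone, is whether an amine or a carboxylic acid at this position would stay within the same scatter, and whether 1H-pyrazol-1-yl would do so alongside the methyl of compound 1.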